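This account rests on a few compounds, and the source may have more. Where it says the series, first, only, none or still open, it means among the compounds named here.

Measured so far:
- compound 1 `CCCCCCCNc1cnc(C(=O)NCc2ccccc2)cn1`: > 100000 nM
- compound 2 `CCCCCNc1nccnc1C(=O)NCc1ccccc1`: >= 100000 nM
- compound 3 `O=C(NCc1ccccc1)c1cncc(Cl)n1`: "not determined" (no result reported)

All three compounds were tested in an ADME assay on HEL cells (Homo sapiens) for cytotoxicity, read by microscopy, with a stated time of 6 days; a lower number here means that less compound is tolerated, a higher number that more compound is tolerated. Compound 1 gives > 100000 nM in this assay, which is a limit of the assay and not a number. Compound 2 gives >= 100000 nM in this assay, again a limit rather than a measured number. Compound 3 has no result reported in this assay. So compound 1 stands on a limit only, one further value is also a limit, and one entry carries no number at all; this is summed up by the limit of > 100000 nM in this assay, at which 1 of the 3 values shown sits, and by the limit of >= 100000 nM in this assay, at which 1 of the 3 values shown sits.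

Compound 4 `CCCCCCCCNc1cnc(C(=O)NCc2ccccc2)cn1` is the next compound to be measured. It differs from compound 1 in one place: methyl in place of hydrogen on a saturated chain carbon, seven bonds along the chain from a nitrogen on an aromatic ring. Nothing in the shown values points in any direction, since no step between measured compounds can be read from limits alone. The step from compound 1 to compound 4 is therefore expected to be none beyond the scatter, so that a number no higher from compound 1 to compound 4 (the limit leaves the size open) is the anticipated change, and compound 4 is most likely to return a limit again. For compound 4 the expected value in this assay is 100000 nM, with a range estimated from 50000 nM to 200000 nM.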

Compound 4, minimum cytotoxic concentration: 100000 nM
Compound 4: the middle estimate sits on the measured number at the digits printed; low and high end bracket the measured number.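

In this assay, compound 4 is the first compound shown with a plain number rather than a limit, so it gives the first actual minimum cytotoxic concentration in this series. Placing methyl in place of hydrogen on a saturated chain carbon, seven bonds along the chain from a nitrogen on an aromatic ring, gives a number no higher from compound 1 to compound 4 (the limit leaves the size open). The direction is all that can be taken from this step, and it may be no real change at all, since the starting value is a limit and the values shown still include it: the limit of > 100000 nM in this assay, at which 1 of the 4 values shown sits.

On these data alone, whether a longer chain would bring the number lower in this assay remains open, as does the effect of ending the chain in an amine or a carboxylic acid. The other steps among these compounds cannot be read, so the shown values do not establish how chain length in general relates to what the cells tolerate.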